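Removing the acetyl from compound 2

A few compounds are considered here, and "the series" means these few. Any claim that something is new, unique, unknown or untested is made for them only; others in the source may bear on it.

Values measured in an ADME assay on cells (Hepatocyte, Mus musculus) for metabolic stability, with a stated time of 30 min (a lower number here means that less of the compound is left, a higher number that more of the compound is left), are as follows
Compound 1 `O=C(OC1CCC(CN2CCN(c3cc(=O)c4cc(C(F)(F)F)cc([N+](=O)[O-])c4s3)CC2)CC1)c1ccncc1` gives 1.4%
Compound 2 `CC(=O)OC1CCC(CN2CCN(c3cc(=O)c4cc(C(F)(F)F)cc([N+](=O)[O-])c4s3)CC2)CC1` gives 0%
Compound 3 `Nc1cc(C(F)(F)F)cc2c(=O)cc(N3CCN(CC4CCCCC4)CC3)sc12` gives 69.4%

In this assay compound 2 with 0% sits level, within the scatter, with compound 1, and both lie far short of compound 3. Compound 4 `O=c1cc(N2CCN(CC3CCC(O)CC3)CC2)sc2c([N+](=O)[O-])cc(C(F)(F)F)cc12` differs from it thus: hydrogen in place of acetyl on an oxygen on a saturated carbon, which turns acetoxy into hydroxy. For the measured compounds named here, the one measured step that bears on this, a number 1.4 percentage points lower from compound 1 to compound 2 (within the scatter), exchanged the group on that carbonyl and stayed within the scatter, but no measured step removes the carbonyl outright. Compound 2 at 0% has no room to fall, so any real change should be upward. The expected step, held with wide uncertainty, is a number 15 percentage points higher from compound 2 to compound 4 (beyond the scatter). The estimate for compound 4 is 15%, with an expected range from 2% to 45%.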

Compound 4, percent of the compound remaining: 51.2%
The estimate for compound 4 lay 36.2 percentage points below the measured number, and the stated range ends below it.
By their numbers in this assay, from the lowest: compounds 2 and 1 (each within the scatter of the next); then compound 4; then compound 3.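

Exchanging the group on the carbonyl had left this assay within the scatter, but removing the acyl group from this oxygen altogether gives a number 51.2 percentage points higher from compound 2 to compound 4 (beyond the scatter) and a number 49.8 percentage points higher from compound 1 to compound 4 (beyond the scatter) on the same change. At this position, acetoxy and its (pyridin-4-yl)carbonyl counterpart therefore read alike, while hydroxy stands clearly apart from both. Nothing measured here accounts for this step.

The compounds shown leave open whether the higher number needs the free hydroxy itself. A methyl ether or an amine on that saturated carbon could separate the two readings.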